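Working notes: propyl extension on the shared core

A few compounds are considered here, and "the series" means these few. Any claim that something is new, unique, unknown or untested is made for them only; others in the source may bear on it.

In a toxicity assay on L02 cells (Homo sapiens) for inhibition, read by CCK-8 assay, with a stated time of 72 h, tested at 20 uM (on this read-out higher numbers stand for more inhibition of growth at the one concentration tested and lower numbers for less inhibition of growth), compound 1 `CCOC(=O)/C=C1/C(=O)Nc2ccccc21` gives 63.9%. In this assay compound 2 `CC(C)(C)OC(=O)/C=C1/C(=O)N(Cc2ccccc2)c2ccccc21` gives 62%, and compound 3 `Cc1ccc2c(c1)/C(=C\C(=O)OC(C)(C)C)C(=O)N2` gives 63.9%. Compound 3 stands level with compound 1 at the digits shown, the two together holding the highest number of the three, and its gap to compound 2 lies within the scatter; the three numbers do not separate from one another. Compound 4 `CCCCc1ccc2c(c1)/C(=C\C(=O)OC(C)(C)C)C(=O)N2` differs from compound 3 by propyl in place of hydrogen on a saturated chain carbon bound to an aromatic carbon. Among the compounds with values here, no measured pair follows such a change, so its size cannot be set against a known step; since the three numbers sit together, no step beyond the scatter is expected in either direction. A step of a number 1.9 percentage points lower from compound 3 to compound 4 (within the scatter) is expected. Compound 4 is estimated at 62%, with a range from 50% to 74%.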

Compound 4, percent growth inhibition at one concentration: 63.7%
Beside the measured number, compound 4's estimate is 1.7 percentage points below it, and the stated range covers the measured number.
By their numbers in this assay, from the lowest: compounds 2, 4, 1 and 3 (each within the scatter of the next).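

In this assay, within the data shown here, propyl in place of hydrogen on a saturated chain carbon bound to an aromatic carbon gives a number 0.2 percentage points lower from compound 3 to compound 4 (within the scatter) and is the first step read at this place on the shared core. Read one bond further out as methyl to butyl, the added chain therefore produces no step beyond the scatter on this read-out. Nothing available bears on why the numbers stay together.

Going by these compounds, whether an amine, a carboxylic acid or a longer chain at this place would stay within the scatter remains open. So does whether propyl would give a similar step on compound 1 or compound 2.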